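The source may hold more compounds than are shown below. What is called first, only, known or untested is meant among the compounds shown, and "the series" means these compounds.

Working notes on the series. Compound 2 `ClCc1ccccc1Cn1cnc2ncnc(Cl)c21` is the point of departure. For the measured compounds named here, in a functional assay on UACC-257 cells (Homo sapiens) for cytotoxicity, read by sulforhodamine B assay, with a stated time of 48 h (on this read-out higher numbers stand for weaker inhibition of growth and lower numbers for stronger inhibition of growth), compound 2 gives 21900 nM, the highest of the three numbers so far. Compound 3 `ClCc1cccc(Cn2cnc3nc(Cl)nc(Cl)c32)c1` gives 15100 nM in this assay, a gap that is within the scatter. Compound 1 `ClCc1cccc(Cn2cnc3c(Cl)nc(Cl)nc32)c1` gives 3460 nM in this assay, a gap that is beyond the scatter. Going by the values given here, no pair of measured compounds differs in one place only, so no counted step is available among them. Compound 4 `ClCc1ccccc1Cn1cnc2nc(Cl)nc(Cl)c21` is not yet measured. It differs from compound 2 by chloro in place of hydrogen on an aromatic carbon. Compound 1 and compound 3 both carry chloro on the aromatic carbon between two ring nitrogen atoms, and compound 1 in this assay sits well below compound 2, so the change is expected to lower the number moderately, probably a step beyond the scatter but not a large one. Compound 4 is expected to give about 11000 nM, with a range from 4000 nM to 30000 nM. The estimated step from compound 2 to compound 4 is a 2.0-fold lower number from compound 2 to compound 4 (0.30 log units; within the scatter).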

Compound 4, concentration for total growth inhibition: 4160 nM
Estimate against measurement, compound 4: 2.6-fold (0.42 log units) above, and the stated range covers the measured number.
By their numbers in this assay, from the lowest: compounds 1 and 4 (each within the scatter of the next); then compounds 3 and 2 (each within the scatter of the next).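

In this assay, for the compounds shown here, chloro in place of hydrogen on the aromatic carbon between two ring nitrogen atoms gives a 5.3-fold lower number from compound 2 to compound 4 (0.72 log units; beyond the scatter), the first counted step. Going by these compounds alone, compound 1 and compound 3 also carry this chloro, but neither has a partner differing in one place, so this is the first direct reading of the change at this position. No available measurement bears on the reason for this step. As far as these compounds go, whether an amine or a methoxy group at this position would give a similar step remains open, as does whether the step would recur with the chloromethyl group placed as in compound 3.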